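Swapping phenoxy for chloro in a cytotoxicity-silent series

This account rests on a few compounds, and the source may have more. Where it says the series, first, only, none or still open, it means among the compounds named here.

In an ADME assay on Raji cells (Homo sapiens) for cytotoxicity, read by luminescence, with a stated time of 72 h (on this read-out lower numbers stand for an effect already at smaller amounts and higher numbers for an effect only at larger amounts of compound), compound 2 (`CCOC(=O)c1c(-c2cccc(Oc3ccccc3)c2)[nH]c2cc(OC)c(Cl)cc2c1=O`) gives > 21500 nM, which is a limit of the assay and not a number. Compound 3 (`CCOC(=O)c1c(-c2cccc(Cl)c2)[nH]c2cc(OC)c(Cl)cc2c1=O`) differs from it by chloro in place of phenoxy on an aromatic carbon, meta to a large group: chloro in place of phenoxy on an aromatic carbon. Compound 1 (`CCOC(=O)c1c(-c2cccc(Cl)c2)[nH]c2cc(OC)ccc2c1=O`), which also bears that chloro group, likewise gives only a limit, > 21500 nM. Within the data shown here, no measured step gives a size for this change, so no shift beyond the scatter is expected in this assay. The expected change is a number no higher from compound 2 to compound 3 (the limit leaves the size open). Compound 3 is estimated at 21500 nM, with an expected range of 12000 nM to 30000 nM.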

Compound 3, half-maximal effective concentration: > 21500 nM
Compound 3 gave a limit, no number (the forecaster's own chance of this, stated with the estimate: 85%); the middle value lies on the limit itself.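

The step from compound 2 to compound 3 and the step from compound 1 to compound 3 cannot be read, as all three compounds rest on one limit: the limit of > 21500 nM in this assay, at which 3 of the 3 values shown sit. The compounds shown leave open whether swapping phenoxy for chloro, or adding chloro in place of hydrogen, changes the concentration giving cytotoxicity at all.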